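The source may report more compounds than this note shows. Statements on the series, on what has been measured and on what is new or still open speak of the compounds shown alone.

Among the compounds with values here, compound 3, `CCNS(=O)(=O)c1ccc(S(=O)(=O)N2CCC[C@@H](C(=O)N3CCN(c4nc(C(C)C)no4)CC3)C2)cc1`, is one of three compounds measured in a functional assay on MIA PaCa-2 cells (Homo sapiens) for inhibition, read by MTT assay, with a stated time of 3 days; on this read-out lower numbers stand for stronger inhibition and higher numbers for weaker inhibition. In this assay compound 3 gives only a limit, > 10000 nM. Compound 1, `CC(C)c1noc(N2CCN(C(=O)[C@@H]3CCCN(S(=O)(=O)c4ccc(S(=O)(=O)C(C)C)cc4)C3)CC2)n1`, carries isopropyl on the sulfonyl sulfur where compound 3 carries ethylamino; in this assay compound 1 likewise gives only a limit, > 10000 nM. Compound 2, `CCN(CC)S(=O)(=O)c1ccc(S(=O)(=O)N2CCC[C@@H](C(=O)N3CCN(C(=O)OC(C)(C)C)CC3)C2)cc1`, gives only a limit as well, > 10000 nM. All three values sit at the limit of > 10000 nM in this assay, at which 3 of the 3 values shown sit, so the step that the two limits leave unreadable from compound 1 to compound 3 cannot be read. Compound 4, `CCN(CC)S(=O)(=O)c1ccc(S(=O)(=O)N2CCC[C@@H](C(=O)N3CCN(c4nc(C(C)C)no4)CC3)C2)cc1`, differs from compound 3 in one place: ethyl in place of hydrogen on a sulfonamide nitrogen. The single step measured between two compounds is unreadable, and no measured step touches a sulfonamide nitrogen, so the numbers shown give neither a size nor a direction for this change. Compound 4 is expected to stay at the limit, and the step that the limit leaves unreadable from compound 3 to compound 4 that this estimate means is none beyond the scatter. The estimate for compound 4 is 15000 nM, between 8000 nM and 40000 nM.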

Compound 4, half-maximal inhibitory concentration: > 10000 nM
Compound 4: a limit, no number (the forecaster's own chance of this, stated with the estimate: 85%); the middle value is on the limit's open side.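

In this assay, within the data shown here, compound 4 gives only a limit of > 10000 nM and so, with compound 1, compound 2 and compound 3 also limits, no step to compound 4 can be read. The compounds shown leave open which change, if any, would give a measurable value.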